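Fluoro for Methyl on the Pendant Ring

This account rests on a few compounds, and the source may have more. Where it says the series, first, only, none or still open, it means among the compounds named here.

Compound 1 `Cc1cccc(-c2nc3cc(C)ccc3c(=O)[nH]2)c1` and compound 2 `Cc1ccc2c(=O)[nH]c(-c3ccccc3C)nc2c1` are built from the same atoms joined differently; the difference between the two cores is not broken down here. In a functional assay on HeLa cells (Homo sapiens) for cytotoxicity, read by MTT assay, with a stated time of 2 days (on this read-out lower numbers stand for stronger inhibition and higher numbers for weaker inhibition), compound 1 gives 11200 nM. Compound 2 reaches only a limit of this assay, > 50000 nM, which is not a number (the limit of > 50000 nM in this assay, at which 1 of the 3 values shown sits). Compound 3 `Cc1ccc2c(=O)[nH]c(-c3ccccc3F)nc2c1` gives 830 nM in this assay. The change fluoro in place of methyl on an aromatic carbon produced an at least 60-fold lower number from compound 2 to compound 3 (1.77 log units; beyond the scatter). Compound 4 `Cc1ccc2c(=O)[nH]c(-c3cccc(F)c3)nc2c1` arises from compound 1 by the same kind of change, (fluoro in place of methyl on an aromatic carbon), though here the fluoro sits meta to a large group rather than ortho to a large group. A lower number is expected for compound 4, estimated as a 3.7-fold lower number from compound 1 to compound 4 (0.57 log units; beyond the scatter), which rests on an at least 60-fold lower number from compound 2 to compound 3 (1.77 log units; beyond the scatter) while allowing for the different place. Compound 4 is therefore expected near 3000 nM, between 800 nM and 12000 nM.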

Compound 4, half-maximal inhibitory concentration: > 50000 nM
Compound 4: no number, only a limit; the forecaster's own chance of this, stated with the estimate: 5%; middle value at least 16-fold (1.22 log units) from the limit.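

In this assay, the change does not carry over from one core to the other: it gives an at least 4.4-fold higher number from compound 1 to compound 4 (0.64 log units; beyond the scatter), against the earlier step in direction and in size: the same change on two cores in this assay, an at least 60-fold lower number (1.77 log units; beyond the scatter) from compound 2 to compound 3 and an at least 4.4-fold higher number (0.64 log units; beyond the scatter) from compound 1 to compound 4, at least 260-fold (2.42 log units) apart, beyond the scatter of two such steps. Neither step has a full size, since each has one end at a limit of the assay, which is not a number: the limit of > 50000 nM in this assay, at which 2 of the 4 values shown sit. The fluoro also sits in a different place in each pair, so these compounds do not show whether the core or the place decides the outcome, and they give no cause for the reversal.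

On these data alone, what stays open is how the change behaves at one fixed place on both cores. Also open, as far as these compounds go, is how another group there, such as methoxy or an amine, would compare.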